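A few compounds are considered here, and "the series" means these few. Any claim that something is new, unique, unknown or untested is made for them only; others in the source may bear on it.

Measured so far:
compound 1 `Nc1nc(Cl)c2ncn(Cc3ccccc3CCl)c2n1` — > 100000 nM
compound 2 `ClCc1ccc(Cn2cnc3c(Cl)nc(Cl)nc32)cc1` — 74100 nM

In a functional assay on A549 cells (Homo sapiens) for cytotoxicity, read by sulforhodamine B assay, with a stated time of 48 h (a higher number here means that more compound is tolerated, a lower number that less compound is tolerated), compound 1 gives only > 100000 nM, which is a limit of the assay and not a number. Compound 1 therefore stands at the limit of > 100000 nM in this assay, at which 1 of the 2 values shown sits. Compound 2 gives 74100 nM in this assay. Compound 3 `ClCc1ccccc1Cn1cnc2c(Cl)ncnc21` is the next member; it differs from compound 1 by hydrogen in place of amino on an aromatic carbon. Going by the values given here, no pair of measured compounds shows this change, so no measured step is available. The expected step of a number no higher from compound 1 to compound 3 (the limit leaves the size open) is small, with no direction beyond the scatter. Compound 3 is estimated at 100000 nM, with a range from 30000 nM to 300000 nM.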

Compound 3, concentration lethal to 50% of the cells: 75900 nM
Compound 3: the middle estimate sits 1.3-fold (0.12 log units) above what was measured, and the stated range covers the measured number.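

Hydrogen in place of amino on the aromatic carbon between two ring nitrogen atoms gives the first step read at this position in this assay, and only its floor can be read: an at least 1.3-fold lower number from compound 1 to compound 3 (0.11 log units; that floor lies within the scatter). For compound 1, > 100000 nM is a limit of the assay and not a number. The full size of the step stays open because compound 1 sits at that limit: the limit of > 100000 nM in this assay, at which 1 of the 3 values shown sits.

The compounds shown leave open how a methylamino or a hydroxyl group on this carbon would read. They also leave open whether any replacement here moves the number beyond the scatter.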